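A Methyl Added Where Only a Stereocentre Had Been Varied

The compounds below may be only part of what the source reports. "The series", "measured", "known", "first", "only" and "open" are said of these compounds alone.

Among the measured compounds shown here, compound 2 `O=C(C[C@@H](NS(=O)(=O)c1ccc2ccccc2c1)c1ccccc1)NCc1ccc(CN2CCCCC2)cc1` holds the lower of the two numbers measured so far in an in vitro assay on CHO-D cells for displacement of a labelled ligand from B1 bradykinin receptor (Homo sapiens); on this read-out higher numbers stand for weaker inhibition and lower numbers for stronger inhibition. In this assay compound 2 gives 132 nM, while compound 1 `O=C(CC(NS(=O)(=O)c1ccc2ccccc2c1)c1ccccc1)NCc1ccc(CN2CCCCC2)cc1` gives 382 nM. For the measured compounds named here, the one measured step, a 2.9-fold lower number from compound 1 to compound 2 (0.46 log units; beyond the scatter), rests on the fact that one of compounds 1 and 2 is drawn with a defined configuration and the other without, at the place where they differ rather than on any change of atoms or bonds.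

Compound 3 `C[C@@H](NC(=O)C[C@@H](NS(=O)(=O)c1ccc2ccccc2c1)c1ccccc1)c1ccc(CN2CCCCC2)cc1` differs from compound 2 by methyl in place of hydrogen on a saturated chain carbon bound to an amide-type nitrogen and an aromatic carbon. Going by the values given here, no measured step touches this kind of change: the single recorded step concerns a drawn configuration at a saturated chain carbon and offers nothing on substitution at a saturated chain carbon bound to an amide-type nitrogen and an aromatic carbon. The expectation for compound 3 in this assay therefore rests on compound 2 alone and carries a wide margin in both directions. The step expected from the methyl, a 1.1-fold higher number from compound 2 to compound 3 (0.06 log units; within the scatter), is set close to none beyond the scatter. Compound 3 is accordingly estimated to give about 150 nM in this assay, within a range from 40 nM to 600 nM.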

Compound 3, inhibition constant: 17 nM
Compound 3: the middle estimate sits 8.8-fold (0.95 log units) above what was measured; measured number outside the range, below it.
By their numbers in this assay, from the lowest: compound 3; then compound 2; then compound 1.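

The chain carbon bound to an amide-type nitrogen and an aromatic carbon proves to be a place where a very small change registers in this assay: methyl in place of hydrogen gives a 7.8-fold lower number from compound 2 to compound 3 (0.89 log units; beyond the scatter) and puts compound 3 lowest of the three compounds. Among the compounds shown here, this step, from the entry of 1 heavy atom with no hydrogen-bond donor or acceptor, is the first evidence on substitution at this carbon, since the earlier step, a 2.9-fold lower number from compound 1 to compound 2 (0.46 log units; beyond the scatter), concerned only a drawn configuration at a different saturated chain carbon. The evidence at hand says nothing about why methyl at this carbon lowers the number.

The compounds shown have only hydrogen or methyl at this carbon and only one drawn configuration of the methyl compound, so it remains open how the opposite configuration there would read. On these data alone, it also remains open whether an ethyl, a hydroxymethyl or a cyclopropyl group at the same carbon would carry the step further, leave it unchanged or reverse it.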